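The source may report more compounds than this note shows. Statements on the series, on what has been measured and on what is new or still open speak of the compounds shown alone.

Measured compounds:
compound 1 `c1ccc(Oc2ccccc2C2=NC(c3ccccc3)CO2)cc1`: 5.61
compound 2 `CCSc1ccccc1C1=NC(c2ccccc2)CO1`: 4.04
compound 3 `Cc1cccc(C2=NC(c3ccccc3)CO2)c1`: 4.11

All three were read in a physicochemical assay for lipophilicity; on this read-out lower numbers stand for lower lipophilicity and higher numbers for higher lipophilicity. In this assay compound 1 gives 5.61, compound 2 gives 4.04 and compound 3 gives 4.11. Among the compounds with values here, compound 2 and compound 3 lie within the scatter of each other, so nothing separates them; compound 1 stands well apart from both, and the only single-point step among the measured compounds, a number 1.57 log units lower from compound 1 to compound 2 (beyond the scatter), records that gap.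

Compound 4 `CSc1ccccc1C1=NC(c2ccccc2)CO1` differs from compound 2 in one place: hydrogen in place of methyl on a saturated chain carbon bound to a sulfur. Cut one bond further out, the change reads ethylsulfanyl to methylsulfanyl. The step from compound 1 to compound 2 is the only measured one touching this part of the shared core, and it was large, but it swapped a whole phenoxy for ethylsulfanyl, whereas here only one carbon is removed. A much smaller move toward lower lipophilicity is therefore expected, at or just beyond the scatter. Compound 4 is estimated at 3.6, between 3.2 and 4. The expected step of a number 0.44 log units lower from compound 2 to compound 4 (beyond the scatter) is thus modest and downward.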

Compound 4, partition coefficient: 3.5
Compound 4: middle estimate off by 0.10 log units, on the high side, within the range that was stated.
By their numbers in this assay, from the lowest: compound 4; then compounds 2 and 3 (each within the scatter of the next); then compound 1.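

In this assay, the change from ethylsulfanyl to methylsulfanyl gives a number 0.54 log units lower from compound 2 to compound 4 (beyond the scatter), so this position responds to the loss of a single carbon from the chain on sulfur, something the earlier swap of a whole phenoxy could not show. Methylsulfanyl in place of phenoxy gives a number 2.11 log units lower from compound 1 to compound 4 (beyond the scatter), which extends the earlier a number 1.57 log units lower from compound 1 to compound 2 (beyond the scatter) and shows that the size of the step from compound 1 depends on which chain sits on the sulfur. Nothing available explains the size of either step.

From the compounds shown here alone, two chains on sulfur are too few to establish a trend, so it remains open whether a longer chain such as propylsulfanyl would continue the same direction. Going by these compounds, the effect of replacing the sulfur, as in methoxy, also remains open.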